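Aryl thioether swap on a nucleoside core: compound 3 to compound 4

The source may hold more compounds than are shown below. What is called first, only, known or untested is meant among the compounds shown, and "the series" means these compounds.

Measured compounds and their values:
Compound 1 `O=[N+]([O-])c1cccc2c1CCN(c1ncnc3c1nc1n3[C@@H]3O[C@H](CO1)[C@@H](O)[C@H]3O)C2`: 7410000 nM
Compound 2 `Nc1nc(SCc2ccccn2)c2ncn([C@@H]3O[C@H](CO)[C@@H](O)[C@H]3O)c2n1`: 34700 nM
Compound 3 `Cc1cc(C)c(SCc2ncnc3c2ncn3[C@@H]2O[C@H](CO)[C@@H](O)[C@H]2O)c(C)c1`: 33100 nM

In an assay on isolated protein for binding affinity to Equilibrative nucleoside transporter 1 (Homo sapiens) (on this read-out higher numbers stand for weaker inhibition and lower numbers for stronger inhibition), compound 3 gives the lowest of the three numbers. Its nearest neighbour is compound 2, whose value lies within the scatter of it, so the two cannot be ordered. Compound 1 stands far beyond the scatter from both. Compound 4 `CC(C)(C)c1ccc(SCc2ncnc3c2ncn3[C@@H]2O[C@H](CO)[C@@H](O)[C@H]2O)cc1` is not yet measured. It differs from compound 3 in one place: 4-(tert-butyl)phenyl in place of 2,4,6-trimethylphenyl on a sulfur. Because compound 3 sits at 33100 nM with an aryl group of similar make-up on the same sulfur, the step of a 1.1-fold lower number from compound 3 to compound 4 (0.04 log units; within the scatter) is expected to stay within the scatter, in no clear direction. Compound 4 is therefore estimated at 30000 nM, with a range from 8000 nM to 120000 nM.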

Compound 4, half-maximal inhibitory concentration: 331000 nM
Compound 4: middle estimate off by 11-fold (1.04 log units), on the low side; measured number outside the range, above it.
By their numbers in this assay, from the lowest: compounds 3 and 2 (each within the scatter of the next); then compound 4; then compound 1.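

In this assay, this sulfur does not treat aryl groups alike: 4-(tert-butyl)phenyl in place of 2,4,6-trimethylphenyl gives a 10-fold higher number from compound 3 to compound 4 (1.00 log units; beyond the scatter) even though the two groups match in ring type, hydrogen-bond counts and net charge. Those shared counts therefore do not predict the outcome at this position. Nothing available accounts for the step.

Still open, from the compounds shown here alone, is how this position responds to an aryl group carrying an amine or a carboxylic acid. A longer chain between the sulfur and the aryl ring also remains untested in the compounds shown.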